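This account rests on a few compounds, and the source may have more. Where it says the series, first, only, none or still open, it means among the compounds named here.

Working notes on the series, read in a functional assay on HT-29 cells (Homo sapiens) for cytotoxicity, read by sulforhodamine B assay; on this read-out higher numbers stand for lower toxicity in this test and lower numbers for higher toxicity in this test. Compound 1 `CC1=CC[C@@H]([C@@](C)(O)CCCC(C)(C)NC(=S)N/N=C\c2ccccc2)CC1` gives 57400 nM and carries an unsubstituted phenyl. Compound 2 `CC1=CC[C@@H]([C@@](C)(O)CCCC(C)(C)NC(=S)N/N=C\c2cccc([N+](=O)[O-])c2)CC1` gives > 100000 nM, which is a limit of the assay and not a number. Its standing is therefore known only as the limit of > 100000 nM in this assay, at which 1 of the 2 values shown sits.

Compound 3 `CC1=CC[C@@H]([C@@](C)(O)CCCC(C)(C)NC(=S)N/N=C\c2cccc(Cl)c2)CC1` is not yet measured. It has chloro in place of nitro on an aromatic carbon, meta to a large group, the change from 3-nitrophenyl to 3-chlorophenyl: chloro in place of nitro on an aromatic carbon.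

Among the measured compounds shown here, one measured step bears on this site: an at least 1.7-fold higher number from compound 1 to compound 2 (0.24 log units; that floor lies within the scatter). For the measured compounds named here, that step put nitro in place of hydrogen, and no compound with chloro has been measured so far. The expectation for this change therefore rests on compound 1 with 57400 nM as the nearest actual number, and no large move is foreseen. The expected step is an at least 1.6-fold lower number from compound 2 to compound 3 (0.22 log units; that floor lies within the scatter), a modest move toward a lower number or none beyond the scatter. For compound 3 the estimated value is 60000 nM, with an expected range from 25000 nM to 130000 nM.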

Compound 3, concentration lethal to 50% of the cells: 45900 nM
Beside the measured number, compound 3's estimate is 1.3-fold (0.12 log units) above it, and the stated range covers the measured number.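

In this assay, among the compounds shown here, the change from 3-nitrophenyl to 3-chlorophenyl gives the first step at this position that clears the scatter, although only as a floor (an at least 2.1-fold lower number from compound 2 to compound 3 (0.33 log units; beyond the scatter)). Chloro in place of hydrogen, by contrast, stays within the scatter (a 1.3-fold lower number from compound 1 to compound 3 (0.10 log units; within the scatter)), so among these three compounds chloro cannot be told apart from the unsubstituted phenyl, while compound 2 separates from compound 3. On these data alone, compound 2 remains a limit of the assay and not a number, so the true size of its step to compound 3 is unknown and only its minimum can be read: the limit of > 100000 nM in this assay, at which 1 of the 3 values shown sits.

The compounds shown leave open how far compound 2 really lies from the other two, and whether the separation from compound 3 is specific to nitro or extends to other groups at this place. An amine or a carboxylic acid on the same aromatic carbon would show whether the number stays with chloro and hydrogen or moves toward the limit held by compound 2.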